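Changing the aryl group on the amide-type nitrogen

The compounds below may be only part of what the source reports. "The series", "measured", "known", "first", "only" and "open" are said of these compounds alone.

Measured so far:
Compound 1 `CCN(CC)CCCNc1nc(-c2ccc(NC(=O)Nc3ccc(F)cc3)cc2)nc2c(Cl)c(Cl)sc12` gives 1700 nM in a functional assay on MKN-45 cells (Homo sapiens) for cytotoxicity, read by MTT assay, with a stated time of 72 h; on this read-out lower numbers stand for stronger inhibition and higher numbers for weaker inhibition.
Compound 2 `CCN(CC)CCCNc1nc(-c2ccc(NC(=O)Nc3ccccc3Cl)cc2)nc2c(Cl)c(Cl)sc12` gives 1450 nM in this assay.

For the measured compounds named here, compound 2 and compound 1 sit within the scatter of each other: the only measured step, a 1.2-fold lower number from compound 1 to compound 2 (0.07 log units; within the scatter), swapped one aryl group for another on the amide-type nitrogen without a shift beyond the noise. Compound 3 `CCN(CC)CCCNc1nc(-c2ccc(NC(=O)Nc3ccc(C)cc3)cc2)nc2c(Cl)c(Cl)sc12` repeats that kind of swap: 4-methylphenyl in place of 2-chlorophenyl on an amide-type nitrogen. Going by the values given here, with the one relevant step flat, no change beyond the scatter is expected, so the estimated step is a 1.0-fold higher number from compound 2 to compound 3 (0.01 log units; within the scatter). Compound 3 is therefore estimated at 1500 nM, with a range from 700 nM to 3200 nM.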

Compound 3, half-maximal inhibitory concentration: 3320 nM
Compound 3: middle estimate off by 2.2-fold (0.35 log units), on the low side; measured number above the stated range.
By their numbers in this assay, from the lowest: compounds 2, 1 and 3 (each within the scatter of the next, the first and the last beyond it).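

The position on the amide-type nitrogen is not fully flat after all: in this assay, 4-methylphenyl in place of 2-chlorophenyl gives a 2.3-fold higher number from compound 2 to compound 3 (0.36 log units; beyond the scatter), a modest change. Methyl in place of fluoro on an aromatic carbon gives a 2.0-fold higher number from compound 1 to compound 3 (0.29 log units; within the scatter), so that swap does not separate its two compounds. Nothing available explains the shift.

Still open, as far as these compounds go, is whether a 4-chlorophenyl or 2-methylphenyl group would sit with compound 2 or compound 3, which would show whether the chlorine or its place counts. From the compounds shown here alone, how a non-aromatic group such as cyclohexyl would behave here is also open.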